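Working notes on hepatic extraction: compound 3 to compound 4

The compounds below may be only part of what the source reports. "The series", "measured", "known", "first", "only" and "open" are said of these compounds alone.

Measured in an ADME assay on microsomes from liver (Rattus norvegicus) for metabolic stability; on this read-out lower numbers stand for lower hepatic extraction and higher numbers for higher hepatic extraction:
compound 1 `Nc1ncnc2c1c(-c1nc3ccc(NS(=O)(=O)c4c(F)cccc4F)cc3[nH]1)cn2C1CCCC1` gives 0.69
compound 2 `Nc1ncnc2c1c(-c1nc3ccc(NC(=O)Nc4c(F)cccc4F)cc3[nH]1)cn2C1CCCC1` gives 0.9
compound 3 `Nc1ncnc2c1c(C(=O)c1cccc(NC(=O)Nc3ccc(Cl)cc3)c1)cn2C1CCCC1` gives 0.7

Compound 3 stands second highest of the three numbers in this assay; compound 1 lies within the scatter of it, while compound 2 sits higher, beyond the scatter. Compound 4 `Cc1ccc(F)c(NC(=O)Nc2cccc(C(=O)c3cn(C4CCCC4)c4ncnc(N)c34)c2)c1` differs from compound 3 by 2-fluoro-5-methylphenyl in place of 4-chlorophenyl on an amide-type nitrogen. Among the compounds with values here, the only measured step, a number 0.21 higher from compound 1 to compound 2 (beyond the scatter), concerns a different change on a different nitrogen, so no measured step bears directly on the present one. With nothing to point either way, the step a number 0.020 higher from compound 3 to compound 4 (within the scatter) is expected to stay within the scatter. Compound 4 is therefore estimated at 0.72, with a range of 0.58 to 0.86 in this assay.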

Compound 4, hepatic extraction ratio: 0.8
Compound 4: middle estimate off by 0.080, on the low side; measured number inside the range.
By their numbers in this assay, from the lowest: compounds 1, 3, 4 and 2 (each within the scatter of the next, the first and the last beyond it).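

Within the data shown here, on the amide-type nitrogen, 2-fluoro-5-methylphenyl in place of 4-chlorophenyl gives a number 0.10 higher from compound 3 to compound 4 (within the scatter) in this assay, the only step read at this position. For this one pair, exchanging one substituted phenyl for the other does not separate the two compounds beyond the scatter. No evidence at hand explains this result.

On these data alone, whether a longer alkyl chain, or a phenyl carrying a carboxylic acid or an amine, on this nitrogen would move hepatic extraction beyond the scatter remains open.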